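The source may hold more compounds than are shown below. What is called first, only, known or untested is meant among the compounds shown, and "the series" means these compounds.

Compound 1 `CCOC(=O)[C@H](CCC(=O)O)NC(=O)c1ccc(CNc2nc3cc(N)cc(N)c3nc2-c2ccccc2)cc1` gives < 100000 nM in a functional assay on OVCAR-4 cells (Homo sapiens) for inhibition, read by sulforhodamine B assay, with a stated time of 48 h (on this read-out higher numbers stand for lower toxicity in this test and lower numbers for higher toxicity in this test), which is a limit of the assay and not a number.
Compound 2 `Nc1cc(N)c2nc(-c3ccccc3)c(NCc3ccc(Cl)c(Cl)c3)nc2c1` gives < 100000 nM in this assay, again a limit of the assay rather than a number.
Compound 3 `CCOC(=O)[C@H](CCC(=O)O)NC(=O)c1ccc(Sc2nc3cc(N)cc(N)c3nc2-c2ccccc2)cc1` gives < 100000 nM in this assay, once more a limit and not a number.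

All three measured compounds share one core and differ only in the group attached to it. None of them has yielded a number in this assay: compound 2, like the other two, stands at the limit of < 100000 nM in this assay, at which 3 of the 3 values shown sit, so where it truly lies within that range is not known from these data.

The unmeasured compound 4 `Nc1cc(N)c2nc(-c3ccccc3)c(NCc3ccc(F)cc3)nc2c1` keeps the core of compound 2 and changes only the group on the benzylic carbon: 4-fluorophenyl in place of 3,4-dichlorophenyl on a saturated chain carbon bound to a nitrogen on an aromatic ring. With no step between measured compounds available for comparison, and every shown value sitting at the same limit, there is nothing to suggest a move in either direction beyond the usual scatter. Compound 4 is therefore expected to give 50000 nM in this assay, most likely reported again as a limit, with a range from 10000 nM to 100000 nM. The expected change from compound 2 is a step that the limit leaves unreadable from compound 2 to compound 4, that is, none beyond the scatter.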

Compound 4, concentration lethal to 50% of the cells: 60300 nM
Compound 4: the middle estimate sits 1.2-fold (0.08 log units) below what was measured; the range from low to high includes it.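

The step between compound 2 and compound 4 cannot be read, as the value of compound 2 in this assay is a limit and not a number: the limit of < 100000 nM in this assay, at which 3 of the 4 values shown sit.

The compounds shown leave open how far 4-fluorobenzyl in place of 3,4-dichlorobenzyl shifts the value, and in which direction.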